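The compounds below may be only part of what the source reports. "The series", "measured", "known", "first", "only" and "open" are said of these compounds alone.

Measured so far:
Compound 1 `Cc1cc(-c2ccc(C#N)cc2)cc(C)c1Nc1ccnc(Nc2ccc(C#N)cc2)n1`: 2080 nM in an ADME assay on MT4 cells (Homo sapiens) for cytotoxicity, read by MTT assay, with a stated time of 4 days; a lower number here means that less compound is tolerated, a higher number that more compound is tolerated.
Compound 2 `Cc1cc(-c2ccc(C(F)(F)F)cc2)cc(C)c1Nc1ccnc(Nc2ccc(C#N)cc2)n1`: 4160 nM in this assay.

Compound 2 sits within the scatter of compound 1; the change a 2.0-fold higher number from compound 1 to compound 2 (0.30 log units; within the scatter) is no more than repeat measurements would give. Compound 3 `Cc1cc(-c2cc(Cl)cc(Cl)c2)cc(C)c1Nc1ccnc(Nc2ccc(C#N)cc2)n1` differs from compound 2 by 3,5-dichlorophenyl in place of 4-(trifluoromethyl)phenyl on an aromatic carbon. Going by the values given here, no measured step exchanges this group for a dichlorophenyl, and the single step at this position, a 2.0-fold higher number from compound 1 to compound 2 (0.30 log units; within the scatter), stayed within the scatter, so nothing beyond the scatter is expected here: a 1.0-fold lower number from compound 2 to compound 3 (0.02 log units; within the scatter). The estimate for compound 3 is 4000 nM, expected range 1500 nM to 10000 nM.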

Compound 3, half-maximal cytotoxic concentration: 4290 nM
For compound 3 the middle estimate is 1.1-fold (0.03 log units) below the measured one; low and high end bracket the measured number.
By their numbers in this assay, from the lowest: compounds 1, 2 and 3 (each within the scatter of the next, the first and the last beyond it).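

In this assay, a ring with two chlorines in place of one with a single trifluoromethyl leaves the number unchanged within the scatter (a 1.0-fold higher number from compound 2 to compound 3 (0.01 log units; within the scatter)). Going by these compounds alone, the step from the 4-cyanophenyl compound is the first at this position printed as beyond the scatter (a 2.1-fold higher number from compound 1 to compound 3 (0.31 log units; beyond the scatter)), but it is modest, and compound 2 lies within the scatter of both neighbours. Nothing measured bears on the origin of these numbers. Still open, as far as these compounds go, is how an amine or a carboxylic acid on this ring would read here, and whether replacing the ring with a longer chain would shift the number further.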